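The compounds below may be only part of what the source reports. "The series", "measured", "known", "first", "only" and "open" are said of these compounds alone.

Working notes on the series. Within the data shown here, compound 2 `CN(C)C(=O)c1cccnc1NCCCN1CCN(c2ccccc2C(F)(F)F)CC1` is the weaker of the two measured members: in a functional assay on aorta for antagonist activity at Alpha-1D adrenergic receptor (Rattus norvegicus) (a higher number here means weaker binding, a lower number tighter binding), compound 2 gives 316 nM, the highest of the two numbers so far, while compound 1 `CN(C)C(=O)c1cccnc1NCCCN1CCN(c2ccccc2O)CC1` gives 63.1 nM in this assay. Among the measured compounds shown here, the single measured step, a 5.0-fold higher number from compound 1 to compound 2 (0.70 log units; beyond the scatter), is the only comparison available and it carries the change of a hydroxy for a trifluoromethyl on the aromatic carbon, a shift beyond the scatter.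

Compound 3 `COc1ccc(N2CCN(CCCNc3ncccc3C(=O)N(C)C)CC2)c(OC)c1` has not yet been measured in this assay. It differs from compound 2 by 2,4-dimethoxyphenyl in place of 2-(trifluoromethyl)phenyl on an amine nitrogen in a ring. For the measured compounds named here, no measured step covers the exchange of a trifluoromethyl for a methoxy, nor the addition of a second methoxy, so the step from compound 1 to compound 2 bears on it only indirectly: it shows that the group on this phenyl moves the number in this assay by a modest amount, and that the trifluoromethyl of compound 2 sits at the weak end of the measured range. On that basis compound 3 is expected to return part of the way toward compound 1, a step of about a 3.2-fold lower number from compound 2 to compound 3 (0.50 log units; beyond the scatter). The estimate for compound 3 in this assay is 100 nM, with a range from 30 nM to 320 nM.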

Compound 3, dissociation constant: 1000 nM
Beside the measured number, compound 3's estimate is 10-fold (1.00 log units) below it; the measured number lies above the stated range.
By their numbers in this assay, from the lowest: compound 1; then compound 2; then compound 3.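

In this assay, among these compounds, the group on the amine nitrogen in the ring spans a wider range than the single earlier step showed, with a 3.2-fold higher number from compound 2 to compound 3 (0.50 log units; beyond the scatter) and a 16-fold higher number from compound 1 to compound 3 (1.20 log units; beyond the scatter) as the two new steps. The 2-(trifluoromethyl)phenyl group of compound 2 no longer marks the weak end of the range. The 2,4-dimethoxyphenyl group of compound 3 now holds that place. Among these three compounds, the numbers rise from 2-hydroxyphenyl through 2-(trifluoromethyl)phenyl to 2,4-dimethoxyphenyl, and no measurement at hand bears on what lies behind this order.

The 2,4-dimethoxyphenyl group differs from the other two groups by more than one feature, so the compounds shown cannot say whether either methoxy alone would account for the higher number, a question that 2-methoxyphenyl and 4-methoxyphenyl groups on the same core would separate. From the compounds shown here alone, it also remains open whether the low number of compound 1 is particular to the hydroxy, or whether an amine on the same aromatic carbon would give a similar result.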